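This account rests on a few compounds, and the source may have more. Where it says the series, first, only, none or still open, it means among the compounds named here.

Measured so far:
Compound 1 `COc1ccccc1-c1nc(Cc2c[nH]c3ccccc23)no1` — 11100 nM
Compound 2 `COc1ccc(OC)c(-c2nc(Cc3c[nH]c4ccccc34)no2)c1` — 8400 nM

In a functional assay on cells (Splenocyte, Mus musculus, strain BALB/c) for inhibition, read by scintillation counting and thymidine incorporation, with stated times of 48 h and 8 h (a lower number here means a stronger inhibitor, a higher number a weaker inhibitor), compound 1 gives the highest of the two numbers, its nearest neighbour being compound 2 at a 1.3-fold lower number from compound 1 to compound 2 (0.12 log units; within the scatter). Compound 3 `Fc1ccccc1-c1nc(Cc2c[nH]c3ccccc23)no1` differs from compound 1 by fluoro in place of methoxy on an aromatic carbon. Among the compounds with values here, the one measured step, methoxy in place of hydrogen on an aromatic carbon, stays within the scatter and does not remove a methoxy, so it bears only loosely on this change. No step beyond the scatter is therefore expected in this assay. Compound 3 is estimated at 11000 nM, between 4000 nM and 30000 nM, which is expected to mean a 1.0-fold lower number from compound 1 to compound 3 (0.00 log units; within the scatter).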

Compound 3, half-maximal inhibitory concentration: > 50000 nM
Compound 3: a limit, no number; the forecaster's own chance of this, stated with the estimate: 10%; middle value at least 4.5-fold (0.65 log units) from the limit.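

In this assay compound 3 gives > 50000 nM, which is a limit of the assay and not a number. Fluoro in place of methoxy on an aromatic carbon ortho to a large group gives an at least 4.5-fold higher number from compound 1 to compound 3 (0.65 log units; beyond the scatter), so this place responds to a change of group beyond the scatter, which the earlier step, methoxy in place of hydrogen, did not show. The limit stands alone among the compounds shown: the limit of > 50000 nM in this assay, at which 1 of the 3 values shown sits.

On these data alone, whether an ethoxy, a hydroxyl or a chlorine here would keep the number of compound 1 stays open. So does the true value of compound 3.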